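The compounds below may be only part of what the source reports. "The series", "measured", "known", "first", "only" and "open" are said of these compounds alone.

Measured so far:
compound 1 `COc1cc(Nc2nc(Cl)cc3c(C(C)C)n[nH]c23)cc(OC)c1OC` — 5.01 nM
compound 2 `COc1cc(Nc2nc(CN)cc3c(-c4ccccc4)n[nH]c23)cc(OC)c1OC` — 22.9 nM

In a functional assay on CHO-K1 cells for antagonist activity at adenosine receptor A1 (Homo sapiens), read by cAMP accumulation, with a stated time of 30 min (on this read-out higher numbers stand for weaker inhibition and lower numbers for stronger inhibition), compound 1 gives 5.01 nM. In this assay compound 2 gives 22.9 nM, the higher of the two numbers; its gap to compound 1 lies beyond the scatter, and the two structures differ in more than one place, so no single change can be read from that pair.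

Compound 3 `COc1cc(Nc2nc(CNCC3CCN(C)CC3)cc3c(-c4ccccc4)n[nH]c23)cc(OC)c1OC` is not yet measured in this assay. It differs from compound 2 by (1-methylpiperidin-4-yl)methyl in place of hydrogen on an amine nitrogen. For the measured compounds named here, no pair of measured compounds shows what an addition on this amine nitrogen does, so the direction of the step is untested. The expectation is a step from compound 2 to compound 3 of a 1.3-fold lower number from compound 2 to compound 3 (0.10 log units; within the scatter), that is, no change beyond the scatter, with some room on either side. Compound 3 is estimated at 18 nM, in the range 5 nM to 65 nM.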

Compound 3, half-maximal inhibitory concentration: 4.68 nM
The estimate for compound 3 lay 3.8-fold (0.59 log units) above the measured number; the measured number lies below the stated range.
By their numbers in this assay, from the lowest: compounds 3 and 1 (each within the scatter of the next); then compound 2.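

Substitution on the amine nitrogen is tolerated in this assay and gives a 4.9-fold lower number from compound 2 to compound 3 (0.69 log units; beyond the scatter) as the first single change in the series that can be read. The hydrogen of the aminomethyl group of compound 2 is therefore not needed for inhibition on this read-out, and (1-methylpiperidin-4-yl)methyl, with its six-membered non-aromatic ring, goes with a lower number rather than a loss. No measurement at hand explains this step.

The compounds shown leave open whether the step belongs to the ring nitrogen, to the ring itself or simply to any addition on this amine nitrogen. A plain methyl on the amine, a cyclohexylmethyl group or a piperidin-4-ylmethyl group without the methyl on its ring nitrogen would separate these readings.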